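This account rests on a few compounds, and the source may have more. Where it says the series, first, only, none or still open, it means among the compounds named here.

Measured compounds:
compound 1 `COc1ccccc1N1C(=O)C(C)SC1c1cccc(C(=O)NCCCCc2ccccc2)c1` with 84%
compound 2 `CCOc1ccccc1N1C(=O)C(C)SC1c1cccc(C(=O)NCCCCc2ccccc2)c1` with 85%
compound 3 `CCN1C(=O)CSC1c1cccc(C(=O)NCCCCc2ccccc2)c1` with 3%

In a functional assay on SJSA-1 cells (Homo sapiens) for inhibition, read by CCK-8 assay, with a stated time of 72 h, tested at 1 uM (a lower number here means less inhibition, a higher number more inhibition at the concentration tested (going by the name of the read-out)), compound 1 and compound 2 give the two higher numbers, and compound 3 gives the lowest of the three; the step from compound 3 to either of them is far beyond the scatter. Compound 4 `Cc1cccc(N2C(=O)CSC2c2cccc(C(=O)NCCCCc3ccccc3)c2)c1` is not yet measured. It differs from compound 3 in one place: 3-methylphenyl in place of ethyl on an amide-type nitrogen in a ring. Among the compounds with values here, the only step measured between neighbours, a number 1 percentage points higher from compound 1 to compound 2 (within the scatter), concerns a different part of the molecule and so does not bear on this change. Still, compound 1 and compound 2, which both carry an aromatic ring on that amide-type nitrogen in a ring, sit high in this assay, while compound 3 with ethyl there sits low, though these pairs also differ elsewhere. On that basis compound 4 is expected to rise in this assay, a number 57 percentage points higher from compound 3 to compound 4 (beyond the scatter), though the size is uncertain. The estimate for compound 4 is 60%, in a range from 20% to 90%.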

Compound 4, a percentage reported as inhibition, at one concentration (the size of the read-out at that concentration, not a potency): 84%
The estimate for compound 4 lay 24 percentage points below the measured number; the measured number falls inside the stated range.
By their numbers in this assay, from the lowest: compound 3; then compounds 1, 4 and 2 (each within the scatter of the next).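

In this assay, within the data shown here, the single change of 3-methylphenyl in place of ethyl on the amide-type nitrogen in a ring gives a number 81 percentage points higher from compound 3 to compound 4 (beyond the scatter) and so ties the contrast to this one position, with the rest of the molecule held the same. The large step shows that the group on this nitrogen, next to the ring atom that bears a large group, can by itself separate a low number from a high one at the concentration tested. No measurement at hand explains the size of this step.

Going by these compounds, it remains open whether the aromatic ring is what counts or whether a saturated group would serve as well, which a cyclohexyl group or a longer chain on this nitrogen would test. On these data alone, the effect of an amine or a carboxylic acid on the 3-methylphenyl ring also remains open.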